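Exchanging the aryl on the ring nitrogen of compound 1

The source may hold more compounds than are shown below. What is called first, only, known or untested is meant among the compounds shown, and "the series" means these compounds.

For the measured compounds named here, compound 1 `Cc1ccc(-n2cnc3cnc(-c4ccc(F)cc4C)cc32)cc1` is the only member of the series with a number in a functional assay on HL-60 cells (Homo sapiens) for activation, read by flow cytometry, with a stated time of 4 days; a lower number here means that less compound is needed, a higher number that more compound is needed for the effect: compound 1 gives 140 nM. Compound 2 `Cc1cc(F)ccc1-c1cc2c(cn1)ncn2-c1ccc(S(C)(=O)=O)cc1` sits at a limit of the assay, (the limit of > 30000 nM in this assay, at which 1 of the 2 values shown sits). In this assay compound 2 gives > 30000 nM, a limit and not a number. Going by the values given here, the single measured step is an at least 210-fold higher number from compound 1 to compound 2 (2.33 log units; beyond the scatter).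

Compound 3 `Cc1cc(F)ccc1-c1cc2c(cn1)ncn2-c1ccc(O)nc1` awaits measurement. It differs from compound 1 by 6-hydroxypyridin-3-yl in place of 4-methylphenyl on an aromatic nitrogen. Among the compounds with values here, the only measured step that bears on this change is the one from compound 1 to compound 2, which also replaced a methyl-bearing part of the aryl group with a group carrying hydrogen-bond acceptors and ran to the limit. A step in the same direction, beyond the scatter, is therefore expected for compound 3, though its size is uncertain and a limit rather than a number is possible. For compound 3 in this assay the estimated value is 3000 nM, expected between 400 nM and 30000 nM, an expected step of a 21-fold higher number from compound 1 to compound 3 (1.33 log units; beyond the scatter).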

Compound 3, half-maximal effective concentration: > 10000 nM
Compound 3 ended at the assay's limit; the forecaster's own chance of this, stated with the estimate: 30%; middle value at least 3.3-fold (0.52 log units) away from the limit.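

A second exchange on the aromatic nitrogen, this time of the whole aryl group, gives an at least 71-fold higher number from compound 1 to compound 3 (1.85 log units; beyond the scatter) in this assay. Compound 3 reads as a limit and not as a number: the limit of > 10000 nM in this assay, at which 1 of the 3 values shown sits. The drop seen with compound 2 is therefore not confined to methylsulfonyl, since 6-hydroxypyridin-3-yl also ends at a limit, and of the three aryl groups shown only 4-methylphenyl gives a number.

Compound 2 and compound 3 both end at limits, so the step between them cannot be read and no order between them can be given. Open too, going by these compounds, is whether pyridin-3-yl without the hydroxyl, 4-methoxyphenyl or an aminophenyl keeps a number in this assay, which would separate the ring nitrogen from the hydroxyl.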